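The compounds below may be only part of what the source reports. "The series", "measured", "known", "first", "only" and "open" are said of these compounds alone.

Three compounds have so far been examined in an ADME assay on HEL cells (Homo sapiens) for cytotoxicity, with a stated time of 3 days; on this read-out higher numbers stand for lower toxicity in this test and lower numbers for higher toxicity in this test. Compound 1 `CCC1(Cc2ccccc2)OS(=O)(=O)CC1=O` gives 200000 nM in this assay, and compound 2 `CC1(C(c2ccccc2)c2ccccc2)OS(=O)(=O)C=C1OCc1ccccc1` gives 200000 nM in this assay. Compound 3 `CCC1(Cc2ccccc2)OS(=O)(=O)C=C1OCc1ccccc1Cl` gives 38000 nM in this assay, the lowest of the three numbers: its distance to compound 1 and its distance to compound 2 are the same, and both lie beyond the usual scatter of repeated measurements, so compound 3 is the most toxic of the three in this assay.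

Compound 4 `CCC1(Cc2ccccc2)OS(=O)(=O)C=C1OCC=C(C)C` has not yet been measured. It differs from compound 3 in one place: 2-methylprop-1-en-1-yl in place of 2-chlorophenyl on a saturated chain carbon bound to an oxygen on an unsaturated carbon. Among the compounds with values here, no pair of measured compounds that differ in a single place is available, so the size of such a step cannot be read off directly. Compound 3 sits below the other two, and the change takes away the chlorine and the aromatic ring; the expectation is a rise in this assay of modest size, possibly beyond the scatter, rather than a fall. Compound 4 is expected to give 100000 nM in this assay, within a range from 30000 nM to 200000 nM. The step of a 2.6-fold higher number from compound 3 to compound 4 (0.42 log units; beyond the scatter) that this estimate means is expected to move toward the numbers of compound 1 and compound 2 without necessarily reaching them.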

Compound 4, half-maximal cytotoxic concentration: 112000 nM
The estimate for compound 4 lay 1.1-fold (0.05 log units) below the measured number; low and high end bracket the measured number.
By their numbers in this assay, from the lowest: compound 3; then compounds 4, 1 and 2 (each within the scatter of the next).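

In this assay, the change at this position gives a 2.9-fold higher number from compound 3 to compound 4 (0.47 log units; beyond the scatter), a modest step but the first single-place difference available in this set. It shows that, with the rest of the structure held constant, the group on a saturated chain carbon bound to an oxygen on an unsaturated carbon is enough to shift this read-out, and that replacing 2-chlorophenyl with 2-methylprop-1-en-1-yl goes with lower toxicity in this test, although neither group carries hydrogen-bond donors, hydrogen-bond acceptors or a net charge. No measurement is at hand that would explain this step.

The change removes the chlorine and the aromatic ring together and brings in a double bond outside aromatic rings, so this single step cannot show which of these differences matters, or whether its direction would hold on another core. The compounds shown also leave open how this read-out would respond to a saturated 3-methylbutyl chain in the same place, which would test the double bond, or to an amine or a carboxylic acid at the end of the chain.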